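A few compounds are considered here, and "the series" means these few. Any claim that something is new, unique, unknown or untested is made for them only; others in the source may bear on it.

Of the compounds shown here, three with a shared core have been measured in a functional assay (thoracic aorta) with Oryctolagus cuniculus as the target; on this read-out lower numbers stand for stronger inhibition and higher numbers for weaker inhibition. Compound 1, `CCOC(=O)N1C(=S)N=C(C)/C(=C(/O)OCC)C1c1cccc([N+](=O)[O-])c1`, gives 3 nM in this assay. Compound 2, `COC(=O)c1cnn2c1N=C(C)/C(=C(\O)OC(C)C)C2c1cccc([N+](=O)[O-])c1`, gives 1160 nM in this assay. Compound 3, `CC1=Nc2cc(=O)n(Cc3ccccc3)n2C(c2cccc([N+](=O)[O-])c2)/C1=C(/O)OC(C)C`, gives 5 nM in this assay. Among these three numbers compound 3 holds the second highest place: its number and that of compound 1 sit within the usual scatter of each other, so no order can be drawn between them, while the number of compound 2 lies far higher and clearly beyond the scatter.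

Compound 4, `CC1=Nc2cc(=O)n(S(=O)(=O)c3ccccc3)n2C(c2cccc([N+](=O)[O-])c2)/C1=C(/O)OC(C)C`, is not yet measured. It differs from compound 3 in one place: phenylsulfonyl in place of benzyl on an aromatic nitrogen. Among the measured compounds shown here, no pair of measured compounds shows this same change, so there is no direct precedent for its effect on this assay. The expectation for compound 4 therefore rests on compound 3 alone, whose 5 nM anchors the guess, with a modest rise in number allowed for an untested change. The step of a 3.0-fold higher number from compound 3 to compound 4 (0.48 log units; beyond the scatter) is thus expected to be small and upward, not far past the scatter. For compound 4 the estimate in this assay is 15 nM, with a range from 3 nM to 80 nM.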

Compound 4, half-maximal inhibitory concentration: 10 nM
For compound 4 the middle estimate is 1.5-fold (0.18 log units) above the measured one; low and high end bracket the measured number.
By their numbers in this assay, from the lowest: compounds 1, 3 and 4 (each within the scatter of the next, the first and the last beyond it); then compound 2.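

Replacing benzyl with phenylsulfonyl on the aromatic nitrogen gives, in this assay, a 2.0-fold higher number from compound 3 to compound 4 (0.30 log units; within the scatter), so no order can be drawn between the two compounds. Among the compounds shown here, this is the first view of how this position responds to a change: the six-membered aromatic ring stays, while the group around it grows from 7 to 9 heavy atoms and goes from 0 to 2 hydrogen-bond acceptors, and the read-out does not move beyond the usual scatter, so the position accepts this particular exchange. Nothing measured here explains why such different links to the ring give numbers this close.

From the compounds shown here alone, both groups seen at this nitrogen carry the same aromatic ring, so it remains open whether the low numbers depend on that ring or would survive a plain methyl, or a chain ending in an amine or a carboxylic acid. Compound 1 and compound 2 differ from these two in more than one place, so they cannot settle this question.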